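Chloro for methyl on the benzyl arm of compound 3

This account rests on a few compounds, and the source may have more. Where it says the series, first, only, none or still open, it means among the compounds named here.

Measured compounds in a functional assay on HT-29 cells (Homo sapiens) for cytotoxicity, read by MTT assay, with a stated time of 24 h; on this read-out higher numbers stand for weaker inhibition and lower numbers for stronger inhibition:
- compound 1 `CN1CCN(CC(=O)Nc2ccc(-c3nc(-c4ccccc4)c(-c4ccccc4)n3C)cc2)CC1`: 35.5 ug/mL
- compound 2 `Cn1c(-c2ccc(NC(=O)CN3CCN(c4ccccc4)CC3)cc2)nc(-c2ccccc2)c1-c1ccccc1`: 8.6 ug/mL
- compound 3 `Cc1ccc(CN2CCN(CC(=O)Nc3ccc(-c4nc(-c5ccccc5)c(-c5ccccc5)n4C)cc3)CC2)cc1`: 62 ug/mL

Compound 3 gives the highest of the three numbers in this assay. Its nearest neighbour is compound 1, with a 1.7-fold higher number from compound 1 to compound 3 (0.24 log units; within the scatter), a step that stays within the scatter. Compound 2 lies furthest away, with a 7.2-fold higher number from compound 2 to compound 3 (0.86 log units; beyond the scatter), a step beyond the scatter. The remaining step, a 4.1-fold lower number from compound 1 to compound 2 (0.62 log units; beyond the scatter), also lies beyond the scatter.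

Compound 4 `Cn1c(-c2ccc(NC(=O)CN3CCN(Cc4ccc(Cl)cc4)CC3)cc2)nc(-c2ccccc2)c1-c1ccccc1` differs from compound 3 by chloro in place of methyl on an aromatic carbon. Going by the values given here, none of the measured steps touches this position: all three alter the group on the amine nitrogen in the ring, not a substituent on the aromatic ring of that group. Among the compounds with values here, the one step that adds this aromatic ring, from compound 1 to compound 3, stayed within the scatter, which suggests the ring itself weighs little here.

For compound 4 the number is therefore expected to stay close to that of compound 3, with the step of a 1.2-fold lower number from compound 3 to compound 4 (0.09 log units; within the scatter) estimated to lie within the scatter. The estimate for compound 4 is 50 ug/mL, expected between 22 ug/mL and 115 ug/mL.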

Compound 4, half-maximal inhibitory concentration: 12 ug/mL
Compound 4: middle estimate off by 4.2-fold (0.62 log units), on the high side; the whole stated range lies above it.
By their numbers in this assay, from the lowest: compounds 2 and 4 (each within the scatter of the next); then compounds 1 and 3 (each within the scatter of the next).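

In this assay, going by these compounds alone, the aromatic carbon para to a large group on the benzyl arm proves to matter: exchanging methyl for chloro there gives a 5.2-fold lower number from compound 3 to compound 4 (0.71 log units; beyond the scatter), a change that no earlier step had probed. With chloro at this place, the 4-chlorobenzyl arm separates from the methyl on the amine nitrogen, with a 3.0-fold lower number from compound 1 to compound 4 (0.47 log units; beyond the scatter), while a 1.4-fold higher number from compound 2 to compound 4 (0.14 log units; within the scatter) leaves it level with the phenyl arm. No measurement in hand offers an explanation for this shift.

The compounds shown leave open how a fluoro, a methoxy or a plain hydrogen would read at this same place, and so whether the shift is particular to chloro or reflects the loss of methyl. They also leave open whether chloro on the phenyl arm of compound 2 would move its number at all.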